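Iodine Exchanged for Bromine on the Aryl Amine

A few compounds are considered here, and "the series" means these few. Any claim that something is new, unique, unknown or untested is made for them only; others in the source may bear on it.

Compound 1 `O=C1C=C(Nc2ccc(I)cc2)C(=O)c2c1nc1n2[C@H]2OC[C@@H](O)[C@H]2OC1` carries a (4-iodophenyl)amino group on the shared core. Among the compounds with values here, in a functional assay on HeLa cells (Homo sapiens) for inhibition, read by sulforhodamine B assay (a lower number here means a stronger inhibitor, a higher number a weaker inhibitor), compound 1 gives 4070 nM, the lowest of the two numbers recorded, while compound 2 `CCCc1ccc(NC2=CC(=O)c3c(nc4n3[C@H]3OC[C@@H](O)[C@H]3OC4)C2=O)cc1` gives 6030 nM, a gap that stays within the scatter, so no order between the pair can be stated. Compound 3 `O=C1C(N2CCCC2)=CC(=O)c2c1nc1n2[C@H]2OC[C@@H](O)[C@H]2OC1` gives > 16000 nM, which is a limit of the assay and not a number. Compound 4 `O=C1C=C(Nc2ccc(Br)cc2)C(=O)c2c1nc1n2[C@H]2OC[C@@H](O)[C@H]2OC1` differs from compound 1 by bromo in place of iodo on an aromatic carbon. Within the data shown here, with no measured step of this kind available, the step from compound 1 to compound 4 is expected to be small, if anything a slight weakening, and no larger than the scatter. Compound 4 is therefore estimated at 5000 nM, within 2500 nM to 10000 nM.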

Compound 4, half-maximal inhibitory concentration: 3830 nM
Estimate against measurement, compound 4: 1.3-fold (0.12 log units) above, within the range that was stated.
By their numbers in this assay, from the lowest: compounds 4, 1 and 2 (each within the scatter of the next). At a limit, above all of these: compound 3.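

In this assay the exchange of halogens reads as a 1.1-fold lower number from compound 1 to compound 4 (0.03 log units; within the scatter), so on this aromatic carbon, para to a large group, iodo and bromo cannot be told apart. Within the data shown here, this is the first single-place step, which the earlier compounds, differing from one another in more than one place, could not give. Nothing measured here accounts for this step. The compounds shown leave open whether chloro, fluoro, an amine or a carboxylic acid on that aromatic carbon would keep the number in this range, and what a plain phenyl would give.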